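The source may report more compounds than this note shows. Statements on the series, on what has been measured and on what is new or still open speak of the compounds shown alone.

Working notes on the series. Compound 1 `COc1cc(/C(Cl)=C/C=C(\C#N)C(=O)c2c(C)[nH]c3ccccc23)cc(OC)c1OC` is the reference point at the potent end. In a functional assay on MCF7 cells (Homo sapiens) for cytotoxicity, read by sulforhodamine B assay, with a stated time of 48 h (a higher number here means a weaker inhibitor of growth, a lower number a stronger inhibitor of growth), compound 1 gives < 100 nM, which is a limit of the assay rather than a number (the limit of < 100 nM in this assay, at which 1 of the 3 values shown sits). Compound 3 `COc1ccc(/C(Cl)=C/C=C(\C#N)C(=O)c2c[nH]c3ccccc23)cc1OC` is a weaker analogue: in this assay compound 3 gives 44200 nM. Compound 2 `N#C/C(=C\C=C(/Cl)c1ccc(Br)cc1)C(=O)c1c[nH]c2ccc(Br)cc12` stands at the far end of the shown values. In this assay compound 2 gives > 100000 nM, a limit of the assay and not a measured number (the limit of > 100000 nM in this assay, at which 1 of the 3 values shown sits). Within the data shown here, no pair of these three differs in a single place, so no single step is quantified among them.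

Compound 4 `COc1ccc2[nH]cc(C(=O)/C(C#N)=C/C=C(\Cl)c3ccc(Br)cc3)c2c1` is the next compound for this assay. It differs from compound 2 by methoxy in place of bromo on an aromatic carbon. Among the measured compounds shown here, no measured step matches this change, so the expectation rests on compound 2 alone: a step not beyond the usual scatter of the assay is anticipated, if anything toward slightly stronger growth inhibition. Compound 4 is expected to give 70000 nM, within 20000 nM to 150000 nM, and the step of an at least 1.4-fold lower number from compound 2 to compound 4 (0.15 log units; that floor lies within the scatter) is thus estimated as small.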

Compound 4, concentration for 50% growth inhibition: 79900 nM
Compound 4: middle estimate off by 1.1-fold (0.06 log units), on the low side; the range from low to high includes it.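

The series now has its first single-place step in this assay, methoxy in place of bromo on an aromatic carbon, and it reads an at least 1.2-fold lower number from compound 2 to compound 4 (0.09 log units; that floor lies within the scatter). Compound 2 sits at a limit of the assay and not at a number, so the step has only a floor and no upper size: the limit of > 100000 nM in this assay, at which 1 of the 4 values shown sits.

With that floor inside the scatter, this change at this position is not shown to move growth inhibition, though a larger step is not excluded.

As far as these compounds go, what an amine or a carboxylic acid on this aromatic carbon would give in this assay remains open. The compounds shown also hold no single-place step linking compound 1 to compound 3, so what separates those two cannot be read.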